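From an Inactive Cyclohexyl Analogue to a Fluorophenyl Analogue

This account rests on a few compounds, and the source may have more. Where it says the series, first, only, none or still open, it means among the compounds named here.

In an assay on CHO cells for antagonist activity at transient receptor potential cation channel subfamily V member 1 (Homo sapiens), read by FLIPR and calcium flux, with a stated time of 6 min (a higher number here means a weaker inhibitor, a lower number a stronger inhibitor), three compounds give the background. Compound 1 `CCCCCn1nc(C(C)(C)C)cc1CNC(=O)C(C)c1ccc(NS(C)(=O)=O)c(F)c1` gives 50.2 nM, and compound 2 `C[C@H](C(=O)NCc1cc(C(C)(C)C)nn1-c1ccc(F)c(Cl)c1)c1ccc(NS(C)(=O)=O)c(F)c1` gives 0.1 nM. Going by the values given here, compound 3 `CC(C)(C)c1cc(CNC(=O)C(c2ccc(NS(C)(=O)=O)c(F)c2)C2CCCCC2)n(-c2cccc(Cl)c2)n1` is recorded as "not active" (no number reported), so no number places it among the others; it stands apart as the one compound without a measured inhibition constant. Compound 4 `CC(C)(C)c1cc(CNC(=O)C(c2cccc(F)c2)c2ccc(NS(C)(=O)=O)c(F)c2)n(-c2cccc(Cl)c2)n1` differs from compound 3 in one place: 3-fluorophenyl in place of cyclohexyl on a saturated chain carbon bound to an aromatic carbon and a carbonyl carbon. Among the compounds with values here, no measured pair shows this change, so the size and direction of the step in this assay are unknown; compound 3 offers no number to step from, and compound 4 could stay inactive or show measurable inhibition. Compound 4 is expected to give roughly 300 nM in this assay, with a range from 20 nM to 5000 nM, and a real chance of another inactive report.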

Compound 4, inhibition constant: "not active" (no number reported)
Compound 4: no number reported, so the estimate cannot be set against anything.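

Compound 3 and compound 4 are both reported as not active in this assay, so no step can be read between them, and no measured evidence bears on this result. As far as these compounds go, whether cyclohexyl and 3-fluorophenyl differ in their effect on inhibition stays open.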